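Hydroxy in place of chloro on a weak antiproliferative compound

A few compounds are considered here, and "the series" means these few. Any claim that something is new, unique, unknown or untested is made for them only; others in the source may bear on it.

Measured in a functional assay on KYSE-410 cells (Homo sapiens) for antiproliferative activity, read by MTT assay, with a stated time of 72 h; a higher number here means a weaker inhibitor, a lower number a stronger inhibitor:
Compound 1 `O=C(Nc1ccc(C(F)(F)F)cc1)c1cc(=O)[nH]c2cc(Br)ccc12` gives > 20000 nM (a limit of the assay)
Compound 2 `O=C(Nc1cc(F)cc(F)c1)c1cc(=O)[nH]c2cc(Br)ccc12` gives 11200 nM
Compound 3 `O=C(Nc1cc(F)cc(F)c1)c1cc(=O)[nH]c2cc(Cl)ccc12` gives 11000 nM

Compound 3 and compound 2 cannot be told apart on these numbers. Going by the values given here, the one measured step between compounds that differ in a single place is a 1.0-fold lower number from compound 2 to compound 3 (0.01 log units; within the scatter), with chloro in place of bromo on an aromatic carbon, and it lies within the scatter. The value of compound 1 is a limit of the assay.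

Compound 4 `O=C(Nc1cc(F)cc(F)c1)c1cc(=O)[nH]c2cc(O)ccc12` keeps the rest of compound 3 and carries hydroxy in place of chloro on an aromatic carbon, meta to a fused ring and para to a fused ring: hydroxy in place of chloro on an aromatic carbon. Among the compounds with values here, the measured step at this place compares bromo with chloro only, and no hydroxy compound has been measured, so it is a weak guide. Within the data shown here, still, the only change measured here stayed within the scatter, so no step beyond the scatter, in either direction, is expected from the value of compound 3 at 11000 nM in this assay. The expected step is a 1.1-fold higher number from compound 3 to compound 4 (0.04 log units; within the scatter). Compound 4 is estimated at 12000 nM, with an expected range from 5000 nM to 25000 nM.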

Compound 4, half-maximal inhibitory concentration: > 20000 nM
Compound 4: a limit, no number (the forecaster's own chance of this, stated with the estimate: 30%); middle value at least 1.6-fold (0.22 log units) from the limit.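

Compound 4 gives > 20000 nM in this assay, which is a limit of the assay and not a number; it is the only compound shown with hydroxy rather than a halogen at this position, so a hydrogen-bond donor and a hydrogen-bond acceptor enter where chloro has neither. The change from chloro is an at least 1.8-fold higher number from compound 3 to compound 4 (0.25 log units; that floor lies within the scatter), and the change from bromo is an at least 1.7-fold higher number from compound 2 to compound 4 (0.25 log units; that floor lies within the scatter), so each can be bounded from one side only, and neither floor alone places the change beyond the scatter. Hydroxy therefore shows no gain over the two halogens, while the true size of any loss stays unknown, and compound 4 now shares its reading with compound 1: the limit of > 20000 nM in this assay, at which 2 of the 4 values shown sit.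

Still open, from the compounds shown here alone, is whether an amine, a methoxy group or a nitrile at this position would give a readable number, and whether any of them would give a lower number than the two halogens. Also open, going by these compounds, is whether hydroxy here would give a readable number with a different group on the benzene ring of the amide.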